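The source may report more compounds than this note shows. Statements on the series, on what has been measured and on what is new or still open speak of the compounds shown alone.

Going by the values given here, in a functional assay on U-251 cells (Homo sapiens) for inhibition, read by colorimetric assay and sulforhodamine B assay, with a stated time of 48 h (a lower number here means a stronger inhibitor of growth, a higher number a weaker inhibitor of growth), compound 2 `CCCCCCCCCCCC[C@@H](O)[C@H]1CC[C@H]([C@H](O)CCCCCCCCCCNC(=O)c2cncs2)O1` gives 100000 nM, the higher of the two numbers measured so far, while compound 1 `CCCCCCCCCCCC[C@@H](O)[C@H]1CC[C@H]([C@H](O)CCCCCCCCCCNC(=O)c2cccs2)O1` gives 2000 nM. Compound 3 `CCCCCCCCCCCC[C@@H](O)[C@H]1CC[C@H]([C@H](O)CCCCCCCCCCNC(=O)c2ccsc2)O1` keeps the shared core and differs from compound 2 in one place, with thiophen-3-yl in place of 1,3-thiazol-5-yl on a carbonyl carbon. Among the compounds with values here, one measured step bears on this change: a 50-fold higher number from compound 1 to compound 2 (1.70 log units; beyond the scatter), where 1,3-thiazol-5-yl took the place of thiophen-2-yl at that same carbonyl carbon. Within the data shown here, compound 3 carries thiophen-3-yl rather than the thiophen-2-yl of compound 1, and no measurement yet shows what that difference does. A large step to a lower number in this assay is therefore expected, close in size to the measured one but possibly smaller. The expected step is a 33-fold lower number from compound 2 to compound 3 (1.52 log units; beyond the scatter). The estimate for compound 3 is 3000 nM, with an expected range of 800 nM to 15000 nM.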

Compound 3, concentration for 50% growth inhibition: 100000 nM
For compound 3 the middle estimate is 33-fold (1.52 log units) below the measured one, and the stated range ends below it.
By their numbers in this assay, from the lowest: compound 1; then compounds 2 and 3 (each within the scatter of the next).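

In this assay, thiophen-3-yl in place of 1,3-thiazol-5-yl on the carbonyl carbon gives no change at the digits printed from compound 2 to compound 3 (within the scatter), so removing the ring nitrogen does not by itself bring the number down. Thiophen-3-yl in place of thiophen-2-yl gives a 50-fold higher number from compound 1 to compound 3 (1.70 log units; beyond the scatter), which shows that two thiophene isomers on the same carbonyl carbon can differ widely and that, of the three groups, only thiophen-2-yl goes with the lower number. Nothing given here explains this difference.

The compounds shown leave open whether the lower number belongs to thiophen-2-yl alone or would also appear with a furan-2-yl or 1,3-thiazol-2-yl group on that carbonyl carbon. They also leave open how a simple phenyl ring would read there.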